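Truncating the side chain of compound 2 to compound 3

The compounds below may be only part of what the source reports. "The series", "measured", "known", "first", "only" and "open" are said of these compounds alone.

Compound 1 `N=C(N)NCCC[C@H](NC(=O)CN(c1nc(Cl)nc2[nH]cnc12)C1CC1)C(=O)O` and compound 2 `CSCC[C@H](NC(=O)CN(c1nc(Cl)nc2[nH]cnc12)C1CC1)C(=O)O` share a core and differ only in the side chain on the saturated chain carbon. In a functional assay on the whole organism (Tail, strain ICR) with Mus musculus as the target, in the tail flick test, with a stated time of 30 min, at a dose of 25 umol/kg by the oral route (a lower number here means a weaker effect, a higher number a stronger effect of the compound at the dose given), compound 1 gives 45.4%, while compound 2 gives 20.4%, the lower of the two numbers. Within the data shown here, the single measured step, a number 25 percentage points lower from compound 1 to compound 2 (beyond the scatter), is the only comparison that bears on the present question, and it concerns the same side chain. Compound 3 `C[C@H](NC(=O)CN(c1nc(Cl)nc2[nH]cnc12)C1CC1)C(=O)O` is not yet measured; it differs from compound 2 by hydrogen in place of (methylsulfanyl)methyl on a saturated chain carbon, two bonds along the chain from an amide-type nitrogen and a carbonyl carbon. Since the one shortening already seen cost a modest amount, a further cut is expected to leave the activity at or somewhat under that of compound 2, with a change estimated at a number 5.4 percentage points lower from compound 2 to compound 3 (within the scatter), inside the scatter. Compound 3 is therefore expected to give about 15%, within 4% to 30%.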

Compound 3, a percentage reported as activity, at one dose (the size of the read-out at that dose, not a potency): 48.1%
Compound 3: middle estimate off by 33.1 percentage points, on the low side; the measured number lies above the stated range.
By their numbers in this assay, from the lowest: compound 2; then compounds 1 and 3 (each within the scatter of the next).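

In this assay, this position does not follow the size of the side chain: hydrogen in place of (methylsulfanyl)methyl gives a number 27.7 percentage points higher from compound 2 to compound 3 (beyond the scatter), so cutting 2-(methylsulfanyl)ethyl back to methyl raises the read-out rather than lowering it further. The large group of compound 1 is also not required for this level of effect at the dose given, as replacing it gives a number 2.7 percentage points higher from compound 1 to compound 3 (within the scatter), and the lowest number therefore belongs to the 2-(methylsulfanyl)ethyl side chain of compound 2 rather than to the shortest chain. Nothing measured here accounts for this behaviour.

On these data alone, it remains open whether the low number of compound 2 goes with the sulfur atom or with the chain itself, which a plain butyl chain in that place would help to settle. An amine or a carboxylic acid at the end of a shorter chain could show whether the group at the chain end matters.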